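From compound 3 to compound 4: a trifluoromethyl group relocated

A few compounds are considered here, and "the series" means these few. Any claim that something is new, unique, unknown or untested is made for them only; others in the source may bear on it.

Compound 1 `C#Cc1cccc(NC(=O)CCc2cccc3c2B(O)OC3)c1`: > 100000 nM, a limit
Compound 2 `O=C(CCc1cccc2c1B(O)OC2)Nc1cccc(-c2cccc(F)c2)c1`: 37000 nM
Compound 3 `O=C(CCc1cccc2c1B(O)OC2)Nc1cccc(-c2cccc(C(F)(F)F)c2)c1`: 23000 nM

In an ADME assay on WI-38 cells (Homo sapiens) for cytotoxicity, read by MTT assay, with a stated time of 72 h (on this read-out lower numbers stand for stronger inhibition and higher numbers for weaker inhibition), compound 3 gives 23000 nM, and it stands level with compound 2: the measured gap is a 1.6-fold lower number from compound 2 to compound 3 (0.21 log units; within the scatter). Only an at least 4.3-fold lower number from compound 1 to compound 3 (0.63 log units; beyond the scatter) is larger, and that step replaces ethynyl, a different kind of change. Compound 4 `O=C(CCc1cccc2c1B(O)OC2)Nc1cccc(-c2ccc(C(F)(F)F)cc2)c1` carries 4-(trifluoromethyl)phenyl in place of 3-(trifluoromethyl)phenyl, on an aromatic carbon meta to a large group: 4-(trifluoromethyl)phenyl in place of 3-(trifluoromethyl)phenyl on an aromatic carbon. The nearest measured precedent is the fluoro to trifluoromethyl exchange in compound 3, a 1.6-fold lower number from compound 2 to compound 3 (0.21 log units; within the scatter), so little movement seems likely. The expected change is a 1.1-fold higher number from compound 3 to compound 4 (0.04 log units; within the scatter), with no shift beyond the scatter anticipated. Compound 4 is estimated at 25000 nM, within an expected range of 12000 nM to 55000 nM.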

Compound 4, half-maximal inhibitory concentration: 26000 nM
Beside the measured number, compound 4's estimate is 1.0-fold (0.02 log units) below it; the range from low to high includes it.
By their numbers in this assay, from the lowest: compounds 3, 4 and 2 (each within the scatter of the next). At a limit, above all of these: compound 1.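

In this assay, the same atoms joined differently give numbers that cannot be told apart, with a 1.1-fold higher number from compound 3 to compound 4 (0.05 log units; within the scatter), so at this position 4-(trifluoromethyl)phenyl and 3-(trifluoromethyl)phenyl read alike. Against the fluoro-bearing ring the picture is the same, with a 1.4-fold lower number from compound 2 to compound 4 (0.15 log units; within the scatter), whereas the ethynyl comparison stands apart, with an at least 3.8-fold lower number from compound 1 to compound 4 (0.58 log units; beyond the scatter). That last step is anchored on compound 1, whose value is a limit and not a number: the limit of > 100000 nM in this assay, at which 1 of the 4 values shown sits.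

Left open is how an amine or a carboxylic acid in place of trifluoromethyl would read in this assay.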